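Swapping the pyridine for a thiazole on the shared core

The source may report more compounds than this note shows. Statements on the series, on what has been measured and on what is new or still open speak of the compounds shown alone.

Three compounds share one core and differ only in the aromatic group on it. Compound 1 `O=C(NCCCCc1ccccc1)n1cc(-c2ccc(Cl)cc2)oc1=O` gives 83 nM in an assay on isolated protein for inhibition of acid ceramidase (Homo sapiens), read by LC-MS, with a stated time of 1 h; on this read-out higher numbers stand for weaker inhibition and lower numbers for stronger inhibition. Compound 2 `COc1ccccc1-c1cn(C(=O)NCCCCc2ccccc2)c(=O)o1` gives 177 nM in this assay, and compound 3 `O=C(NCCCCc1ccccc1)n1cc(-c2cccnc2)oc1=O` gives 70 nM. Compound 3 thus has the lowest of the three numbers: the step of a 1.2-fold lower number from compound 1 to compound 3 (0.07 log units; within the scatter) lies within the scatter, whereas a 2.5-fold lower number from compound 2 to compound 3 (0.40 log units; beyond the scatter) and a 2.1-fold higher number from compound 1 to compound 2 (0.33 log units; beyond the scatter) lie beyond it. Compound 4 `O=C(NCCCCc1ccccc1)n1cc(-c2cscn2)oc1=O` carries a smaller ring: 1,3-thiazol-4-yl in place of pyridin-3-yl on an aromatic carbon. Every measured step exchanged one six-membered ring for another, so none speaks directly to a five-membered ring; the two modest steps suggest the aromatic group matters little. The expected step is a 1.3-fold higher number from compound 3 to compound 4 (0.11 log units; within the scatter), within the scatter. Compound 4 is estimated at 90 nM, between 40 nM and 200 nM.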

Compound 4, half-maximal inhibitory concentration: 44 nM
Compound 4: the middle estimate sits 2.0-fold (0.31 log units) above what was measured; low and high end bracket the measured number.
By their numbers in this assay, from the lowest: compounds 4, 3 and 1 (each within the scatter of the next); then compound 2.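

This position accepts a five-membered aromatic ring as readily as a six-membered one: 1,3-thiazol-4-yl gives a 1.6-fold lower number from compound 3 to compound 4 (0.20 log units; within the scatter) and a 1.9-fold lower number from compound 1 to compound 4 (0.28 log units; within the scatter) and both steps stay within the scatter. Only against the 2-methoxyphenyl group does it separate clearly, with a 4.0-fold lower number from compound 2 to compound 4 (0.60 log units; beyond the scatter) as the largest step in this small set. Nothing available here explains these differences.

Every group shown at this position is an aromatic ring. As far as these compounds go, whether an amine or a carboxylic acid placed there would keep inhibition of this kind remains open.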